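Aryl piperazine variation on a sulfonyl-benzamide hexyl chain

The source may hold more compounds than are shown below. What is called first, only, known or untested is meant among the compounds shown, and "the series" means these compounds.

Compound 1 `O=C1c2ccccc2S(=O)(=O)N1CCCCCCN1CCN(c2cccc(Cl)c2Cl)CC1`: in an ADME assay on HEK293 cells for displacement of a labelled ligand from 5-hydroxytryptamine receptor 6 (Homo sapiens), read by radioligand binding, with a stated time of 1 h (a higher number here means a weaker inhibitor, a lower number a stronger inhibitor), compound 1 gives 920 nM
Compound 2 `O=C1c2ccccc2S(=O)(=O)N1CCCCCCN1CCN(c2ccccc2C(F)(F)F)CC1`: in this assay compound 2 gives 1270 nM
Compound 3 `O=C1c2ccccc2S(=O)(=O)N1CCCCCCN1CCN(c2cccc3ccccc23)CC1`: in this assay compound 3 gives 157 nM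

Compound 3 holds the lowest of the three numbers: a 5.9-fold lower number from compound 1 to compound 3 (0.77 log units; beyond the scatter) and an 8.1-fold lower number from compound 2 to compound 3 (0.91 log units; beyond the scatter), both beyond the scatter, whereas a 1.4-fold higher number from compound 1 to compound 2 (0.14 log units; within the scatter) lies within it. Compound 4 `O=C1c2ccccc2S(=O)(=O)N1CCCCCCN1CCN(c2ncccn2)CC1` differs from compound 3 by pyrimidin-2-yl in place of naphthalen-1-yl on an amine nitrogen in a ring. Every measured step exchanges one group on the same ring nitrogen, and the two that reach compound 3 are modest, setting the naphthalen-1-yl compound apart from the two substituted phenyls. Among the compounds with values here, no measured step covers a pyrimidin-2-yl group or any ring with hetero atoms, so the expectation rests on compound 3 being the outlier. For compound 4 a step back toward, or past, compound 1 and compound 2 is expected: a 9.6-fold higher number from compound 3 to compound 4 (0.98 log units; beyond the scatter). In this assay compound 4 is estimated at 1500 nM, between 400 nM and 6000 nM.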

Compound 4, inhibition constant: 104 nM
Compound 4: middle estimate off by 14-fold (1.16 log units), on the high side; measured number outside the range, below it.
By their numbers in this assay, from the lowest: compounds 4 and 3 (each within the scatter of the next); then compounds 1 and 2 (each within the scatter of the next).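

At this ring nitrogen, a ring with hetero atoms groups with the naphthalen-1-yl compound and not with the substituted phenyls: a 1.5-fold lower number from compound 3 to compound 4 (0.18 log units; within the scatter) stays within the scatter, while a 12-fold lower number from compound 2 to compound 4 (1.09 log units; beyond the scatter) and an 8.8-fold lower number from compound 1 to compound 4 (0.95 log units; beyond the scatter) lie beyond it in this assay. Among these compounds, a low number therefore does not depend on the second carbon ring of naphthalen-1-yl, since one six-membered aromatic ring with hetero atoms gives a matching result. Nothing on hand gives a cause for this.

Still open, going by these compounds, is how an unsubstituted phenyl or a pyridin-2-yl group on this nitrogen compares with pyrimidin-2-yl. Also open, on these data alone, is whether a butyl chain in place of hexyl keeps the number of compound 4 .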